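From a hydroxyethyl arm to a difluorophenyl ring

A few compounds are considered here, and "the series" means these few. Any claim that something is new, unique, unknown or untested is made for them only; others in the source may bear on it.

Compound 1 `O=c1cc(Cn2cc(CCO)nn2)c2ccc(O)cc2o1`, compound 2 `CC(O)c1cn(Cc2cc(=O)oc3cc(O)ccc23)nn1` and compound 3 `CCCCCCCCc1cn(Cc2cc(=O)oc3cc(O)ccc23)nn1` share one core and differ only in the group carried on the five-membered aromatic ring with 3 nitrogen. In a functional assay on A549 cells (Homo sapiens) for inhibition, read by MTT assay, with a stated time of 72 h (a higher number here means a weaker inhibitor, a lower number a stronger inhibitor), compound 1 gives 90300 nM and compound 3 gives 46000 nM. For compound 2 the assay reports only a limit, > 100000 nM, so compound 2 stands at the weak end of the numbers shown (the limit of > 100000 nM in this assay, at which 1 of the 3 values shown sits). Among the compounds with values here, the step of an at least 1.1-fold higher number from compound 1 to compound 2 (0.04 log units; that floor lies within the scatter) is small, whereas the step of an at least 2.1-fold lower number from compound 2 to compound 3 (0.33 log units; beyond the scatter) is the one that bears on compound 4 `O=c1cc(Cn2cc(-c3cc(F)cc(F)c3)nn2)c2ccc(O)cc2o1`, since it too exchanges the 1-hydroxyethyl group for a group of a different kind. Compound 4 differs from compound 2 by 3,5-difluorophenyl in place of 1-hydroxyethyl on an aromatic carbon. By analogy with compound 3, a modest lowering of the number is expected, with an estimated step of an at least 2.5-fold lower number from compound 2 to compound 4 (0.39 log units; beyond the scatter). Compound 4 is therefore expected to give about 40000 nM in this assay, most likely between 15000 nM and 100000 nM.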

Compound 4, half-maximal inhibitory concentration: 21100 nM
Compound 4: the middle estimate sits 1.9-fold (0.28 log units) above what was measured, within the range that was stated.
By their numbers in this assay, from the lowest: compound 4; then compounds 3 and 1 (each within the scatter of the next). At a limit, above all of these: compound 2.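

In this assay, an aromatic ring on this carbon of the five-membered aromatic ring with 3 nitrogen gives a lower number than either chain with a measured value, with a 4.3-fold lower number from compound 1 to compound 4 (0.63 log units; beyond the scatter) and a 2.2-fold lower number from compound 3 to compound 4 (0.34 log units; beyond the scatter), whereas compounds 1 and 3 lay within the scatter of each other. Against compound 2 the change reads as an at least 4.7-fold lower number from compound 2 to compound 4 (0.67 log units; beyond the scatter), which is a floor and not an exact size. Compound 2 is known only by a limit: the limit of > 100000 nM in this assay, at which 1 of the 4 values shown sits.

Still open, on these data alone, is whether the lower number goes with the aromatic ring or with its fluorine atoms, a question that a plain phenyl group on this aromatic carbon would address. Also open, as far as these compounds go, is how an amine or a carboxylic acid on that phenyl ring would read in this assay.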